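A Second Chloro on the Core: What Compound 4 May Give

The source may hold more compounds than are shown below. What is called first, only, known or untested is meant among the compounds shown, and "the series" means these compounds.

Compound 1 `ClCc1ccc(Cn2cnc3c(Cl)ncnc32)cc1`: 3980 nM
Compound 2 `ClCc1ccccc1Cn1cnc2c(Cl)ncnc21`: 38000 nM
Compound 3 `ClCc1cccc(Cn2cnc3c(Cl)ncnc32)c1`: 20000 nM

These three compounds were tested in a functional assay on 786-0 cells (Homo sapiens) for cytotoxicity, read by sulforhodamine B assay, with a stated time of 48 h; a lower number here means a stronger inhibitor of growth, a higher number a weaker inhibitor of growth. Compound 1 gives the lowest number of the three; compound 3 gives a higher number, beyond the scatter, and compound 2 a higher number still. Compound 4 `ClCc1ccc(Cn2cnc3c(Cl)nc(Cl)nc32)cc1` has not yet been measured. It differs from compound 1 in one place: chloro in place of hydrogen on an aromatic carbon, in words, chloro in place of hydrogen on an aromatic carbon. Within the data shown here, no measured pair among the three compounds shows this kind of change, so the size of the step in this assay is uncertain; a small shift in either direction, or none beyond the scatter, seems equally plausible. Compound 4 is estimated at 3000 nM, with a range from 800 nM to 12000 nM. That estimate means an expected step of a 1.3-fold lower number from compound 1 to compound 4 (0.12 log units; within the scatter).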

Compound 4, concentration for total growth inhibition: 29500 nM
Estimate against measurement, compound 4: 9.8-fold (0.99 log units) below, outside the stated range (above it).
By their numbers in this assay, from the lowest: compound 1; then compounds 3, 4 and 2 (each within the scatter of the next).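

Placing chloro on this carbon, between two ring nitrogen atoms, gives a 7.4-fold higher number from compound 1 to compound 4 (0.87 log units; beyond the scatter) in this assay and so weakens growth inhibition. Among these compounds, the earlier compounds all carry hydrogen here, so this is the first sign that the position responds to substitution. No measurement shown explains the step. Going by these compounds, it remains open whether the loss is specific to chloro or would also follow from another group here, such as an amine or a methoxy group. A single step also cannot show how other groups would rank at this position.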